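This account rests on a few compounds, and the source may have more. Where it says the series, first, only, none or still open, it means among the compounds named here.

Compound 3 `CCOC(=O)C1=Cc2ccccc2OC1(OCc1cn(-c2ccccc2)nn1)C(F)(F)F` was tested in a functional assay on HeLa cells (Homo sapiens) for inhibition, read by MTT assay, with a stated time of 24 h; on this read-out higher numbers stand for weaker inhibition and lower numbers for stronger inhibition. In this assay compound 3 gives > 150000 nM, which is a limit of the assay and not a number. Two close relatives were run in the same way. Compound 1 `CCOC(=O)C1=Cc2ccccc2OC1(OCc1cc(-c2ccc(F)cc2F)no1)C(F)(F)F` gives in this assay > 150000 nM, again a limit. Compound 2 `CCOC(=O)C1=Cc2ccccc2OC1(OCc1cc(-c2ccc(C)cc2)no1)C(F)(F)F` gives in this assay > 150000 nM, also a limit. The only one-place step among these three, a step that the two limits leave unreadable from compound 1 to compound 2, cannot be read as a size, as both of its ends are limits. The whole picture is thus (the limit of > 150000 nM in this assay, at which 3 of the 3 values shown sit), and nothing more detailed.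

Compound 4 `CCOC(=O)C1=Cc2ccccc2OC1(OCc1cn(-c2cccc(C(F)(F)F)c2)nn1)C(F)(F)F` differs from compound 3 by trifluoromethyl in place of hydrogen on an aromatic carbon. Among the measured compounds shown here, no measured step speaks to this change: the one recorded step is unreadable, so no direction and no size can be drawn from it, and the three limits make it likely that compound 4 will also be reported as a limit. Compound 4 is therefore expected to give 150000 nM, with a range from 40000 nM to 400000 nM. The expected step is a number no higher from compound 3 to compound 4 (the limit leaves the size open), meaning no change beyond the scatter is anticipated.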

Compound 4, half-maximal inhibitory concentration: > 150000 nM
Compound 4 was reported as a limit (the forecaster's own chance of this, stated with the estimate: 85%); the middle value sits exactly at the limit.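

No size or direction can be read for trifluoromethyl in place of hydrogen between compound 3 and compound 4, as both results are limits and not numbers. The picture stays flat: the limit of > 150000 nM in this assay, at which 4 of the 4 values shown sit.

The compounds shown leave open whether any change to them can bring a measurable value in this assay.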